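The source may hold more compounds than are shown below. What is called first, only, known or untested is meant among the compounds shown, and "the series" means these compounds.

Measured so far:
- compound 1, `Cn1c(=O)c(=O)n(C2CCCC2)c2nc(N/N=C/c3ccc(Cl)cc3)ncc21`: 8420 nM
- compound 2, `Cn1c(=O)c(=O)n(C2CCCC2)c2nc(N/N=C/c3ccc(O)c(F)c3)ncc21`: 85200 nM
- compound 3, `Cn1c(=O)c(=O)n(C2CCCC2)c2nc(N/N=C/c3ccc(C(F)(F)F)cc3)ncc21`: 23600 nM

In a functional assay on PC-3 cells (Homo sapiens) for antiproliferative activity, read by MTT assay (on this read-out lower numbers stand for stronger inhibition and higher numbers for weaker inhibition), compound 3 stands second highest of the three numbers; the nearest is compound 1, below it by a 2.8-fold higher number from compound 1 to compound 3 (0.45 log units; beyond the scatter), the furthest compound 2, above it by a 3.6-fold lower number from compound 2 to compound 3 (0.56 log units; beyond the scatter). Compound 4, `Cc1ccc(/C=N/Nc2ncc3c(n2)n(C2CCCC2)c(=O)c(=O)n3C)cc1C`, is not yet measured. The change from compound 3 is 3,4-dimethylphenyl in place of 4-(trifluoromethyl)phenyl on a carbon with a double bond to nitrogen.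

The measured steps that bear on this all replace the aryl group on the carbon with a double bond to nitrogen: a 2.8-fold higher number from compound 1 to compound 3 (0.45 log units; beyond the scatter) and a 3.6-fold lower number from compound 2 to compound 3 (0.56 log units; beyond the scatter) are both modest, while a 10-fold higher number from compound 1 to compound 2 (1.01 log units; beyond the scatter) is large. For the measured compounds named here, every swap of that aryl group so far moved the number beyond the scatter, so a step in this assay is expected for compound 4 as well, though none of the measured compounds carries a 3,4-dimethylphenyl and the direction is uncertain; a modest lowering is taken as the more likely outcome, estimated as a 2.0-fold lower number from compound 3 to compound 4 (0.29 log units; within the scatter). Compound 4 is therefore expected to give 12000 nM, between 3500 nM and 40000 nM.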

Compound 4, half-maximal inhibitory concentration: 39000 nM
Estimate against measurement, compound 4: 3.3-fold (0.51 log units) below; low and high end bracket the measured number.
By their numbers in this assay, from the lowest: compound 1; then compounds 3 and 4 (each within the scatter of the next); then compound 2.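

In this assay, for the compounds shown here, the swap to 3,4-dimethylphenyl gives a 1.7-fold higher number from compound 3 to compound 4 (0.22 log units; within the scatter) and is the first change of aryl group on the carbon with a double bond to nitrogen to stay within the scatter, so 4-(trifluoromethyl)phenyl and 3,4-dimethylphenyl are not told apart here. The same group remains separated from the other two aryl groups, with a 2.2-fold lower number from compound 2 to compound 4 (0.34 log units; beyond the scatter) and a 4.6-fold higher number from compound 1 to compound 4 (0.67 log units; beyond the scatter) both beyond the scatter, and compound 1 remains the most potent of the four in this read-out. Nothing available gives a reason for these differences.

As far as these compounds go, whether an aryl group carrying an amine or a carboxylic acid would change the number at this place remains open. So does whether a longer chain on the aryl group would bring it under the value of compound 1.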